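This account rests on a few compounds, and the source may have more. Where it says the series, first, only, none or still open, it means among the compounds named here.

Compound 1 `N#Cc1ccc(Nc2nccc(Oc3ccc(-c4ccc(C#N)cc4)cc3F)n2)cc1` is the reference point of this set. In a functional assay on MT4 cells (Homo sapiens) for cytotoxicity, read by MTT assay, with a stated time of 5 days (a lower number here means that less compound is tolerated, a higher number that more compound is tolerated), compound 1 gives > 307000 nM, which is a limit of the assay and not a number. Compound 2 `N#Cc1ccc(Nc2nccc(Oc3ccc(-c4ccc(C#N)cc4)c(F)c3F)n2)cc1`, carrying fluoro in place of hydrogen on an aromatic carbon, gives in this assay the value > 294000 nM, again only a limit. Compound 3 `COc1cc(-c2ccc(C#N)cc2)ccc1Oc1ccnc(Nc2ccc(C#N)cc2)n1`, with methoxy in place of fluoro on an aromatic carbon, gives in this assay the value > 298000 nM, likewise a limit. The steps a step that the two limits leave unreadable from compound 1 to compound 2 and a step that the two limits leave unreadable from compound 1 to compound 3 therefore cannot be sized. For compound 1 the relevant line is the limit of > 307000 nM in this assay, at which 1 of the 3 values shown sits. For compound 2 it is the limit of > 294000 nM in this assay, at which 1 of the 3 values shown sits. For compound 3 it is the limit of > 298000 nM in this assay, at which 1 of the 3 values shown sits.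

Compound 4 `Cc1cc(C#N)ccc1-c1ccc(Oc2ccnc(Nc3ccc(C#N)cc3)n2)c(F)c1` has yet to be measured. It differs from compound 1 by methyl in place of hydrogen on an aromatic carbon. Among the compounds with values here, no measured step bears directly on this change; the two steps available are unreadable, and all three measured values of the shared core sit at limits. The expectation for compound 4 is accordingly a step of an at least 1.0-fold lower number from compound 1 to compound 4 (0.01 log units; that floor lies within the scatter) of no readable size, most probably a further limit. Compound 4 is estimated at 300000 nM, with a range from 150000 nM to 600000 nM.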

Compound 4, half-maximal cytotoxic concentration: > 296000 nM
Compound 4 ended at the assay's limit; the forecaster's own chance of this, stated with the estimate: 85%; the middle value does not contradict the limit.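

In this assay compound 4 gives > 296000 nM, a limit of the assay and not a number. Within the data shown here, compound 1 gives > 307000 nM, likewise a limit, so no step between compound 1 and compound 4 can be read. The compounds shown leave open the half-maximal cytotoxic concentration of compound 1, compound 2, compound 3 and compound 4, and whether any change on the shared core shifts it.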